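Sulfonyl aryl change from compound 1 to compound 3

This account rests on a few compounds, and the source may have more. Where it says the series, first, only, none or still open, it means among the compounds named here.

Readings in a functional assay on LOX IMV1 cells (Homo sapiens) for antiproliferative activity (on this read-out higher numbers stand for weaker inhibition of growth and lower numbers for stronger inhibition of growth), so far:

- Compound 1 (`CC(=O)Nc1ccc(S(=O)(=O)NNC(=O)c2cccnc2Nc2ccc(Cl)cc2)cc1`) gives > 100000 nM (a limit)
- Compound 2 (`O=C(NNS(=O)(=O)c1ccc(F)cc1)c1cccnc1Nc1ccc(Cl)cc1Cl`) gives > 100000 nM (a limit)

Going by the values given here, compound 1 stands at a limit, not at a number, and no measured step is available to scale from. Compound 3 (`O=C(NNS(=O)(=O)c1ccc(Cl)cc1Cl)c1cccnc1Nc1ccc(Cl)cc1`) keeps the core of compound 1 and carries 2,4-dichlorophenyl in place of 4-acetamidophenyl on a sulfonyl sulfur. A small change toward stronger inhibition of growth is expected, with compound 3 staying close to the limit because of the limit of > 100000 nM in this assay, at which 2 of the 2 values shown sit. The expected change in this assay is an at least 1.6-fold lower number from compound 1 to compound 3 (0.22 log units; that floor lies within the scatter) as estimated. For compound 3 the estimated value is 60000 nM, with an expected range from 15000 nM to 100000 nM.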

Compound 3, concentration for total growth inhibition: 46800 nM
Compound 3: middle estimate off by 1.3-fold (0.11 log units), on the high side, within the range that was stated.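

In this assay, compound 3 is the only one of the three compounds shown to give a number rather than a limit, so the aryl group on a sulfonyl sulfur can move this series into the measurable range. Placing 2,4-dichlorophenyl there in place of 4-acetamidophenyl gives an at least 2.1-fold lower number from compound 1 to compound 3 (0.32 log units; beyond the scatter). On these data alone, the full size of this step stays unknown because compound 1 stands at a limit: the limit of > 100000 nM in this assay, at which 2 of the 3 values shown sit.

Still open, as far as these compounds go, is whether both chlorines are needed. A methoxy group or a carboxylic acid on that phenyl ring could also test how far a measurable value persists.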